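Methyl on the ring amine nitrogen: two matched pairs

The source may hold more compounds than are shown below. What is called first, only, known or untested is meant among the compounds shown, and "the series" means these compounds.

Measured so far, in an in vitro assay on SH-SY5Y cells for displacement of a labelled ligand from Neuronal acetylcholine receptor; alpha3/beta4 (Homo sapiens); a lower number here means a stronger inhibitor, a higher number a weaker inhibitor:
compound 1, `Fc1ccc(C2=CC3CNCC(C2)C3)cn1`, gives 28 nM;
compound 2, `C1=C(c2cccnc2)C[C@@H]2CNC[C@H]1C2`, gives 23 nM;
compound 3, `CN1CC2C=C(c3ccc(F)nc3)CC(C2)C1`, gives 1310 nM.

Compound 1 and compound 2 carry different cores; the difference between the two cores is not broken down here. Their numbers in this assay lie within the scatter of each other, so nothing separates them on this read-out.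

Compound 3 is compound 1 with one change, (methyl in place of hydrogen on an amine nitrogen in a ring), and this single change gives a 47-fold higher number from compound 1 to compound 3 (1.67 log units; beyond the scatter). Going by the values given here, that is the only measured step in the set, and it is large.

Compound 4, `CN1C[C@@H]2C=C(c3cccnc3)C[C@@H](C2)C1`, is not yet measured. It stands to compound 2 as compound 3 stands to compound 1: the change is methyl in place of hydrogen on an amine nitrogen in a ring, and the place is described in the same words for both pairs, so it is the same change made on the other core.

Among the compounds with values here, with only one measured instance of this change, the expectation for compound 4 rests entirely on compound 3, whose step from compound 1 is a 47-fold higher number from compound 1 to compound 3 (1.67 log units; beyond the scatter). A step of similar size is expected here, a 39-fold higher number from compound 2 to compound 4 (1.59 log units; beyond the scatter), starting from compound 2 at 23 nM. Compound 4 is therefore estimated at 900 nM in this assay, with a likely range from 250 nM to 3500 nM; the width allows for the chance that the second core responds less or more to the same change than the first did.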

Compound 4, inhibition constant: 1800 nM
For compound 4 the middle estimate is 2.0-fold (0.30 log units) below the measured one; the range from low to high includes it.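

In this assay, methyl in place of hydrogen on an amine nitrogen in a ring gives a 78-fold higher number from compound 2 to compound 4 (1.89 log units; beyond the scatter). Set beside the earlier step, the change carries from one core to the other as a large move towards a higher number, and the two steps cannot be told apart in size: the same change on two cores in this assay, a 47-fold higher number (1.67 log units; beyond the scatter) from compound 1 to compound 3 and a 78-fold higher number (1.89 log units; beyond the scatter) from compound 2 to compound 4, 1.7-fold (0.22 log units) apart, within the scatter of two such steps. This shows that, for these two matched pairs, the step measured on one core was a fair guide to the direction and rough size of the step on the other; it does not show that the same would hold on a third core, and two pairs give no account of why the change has this effect.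

The compounds shown leave open how the same ring amine nitrogen responds to other groups in place of hydrogen, such as ethyl, a longer chain or an acetyl group, and whether the step grows, levels off or shrinks with them. Also open, on these data alone, is whether the size of this step holds in any read-out other than this one, as all four compounds are compared here on a single binding measurement.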